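This account rests on a few compounds, and the source may have more. Where it says the series, first, only, none or still open, it means among the compounds named here.

In a functional assay (Platelet, plasma) for inhibition, with Homo sapiens as the target (a higher number here means a weaker inhibitor, a lower number a stronger inhibitor), compound 2 `N#Cc1ccc(CS(=O)(=O)NC(=O)C2CCN(c3nc4c(cc3C#N)C(=O)OC4)CC2)cc1` gives 8900 nM. Compound 1 `N#Cc1cc2c(nc1N1CCC(C(=O)NS(=O)(=O)Cc3ccccc3F)CC1)COC2=O` gives 23700 nM, which leaves compound 2 with the lower of the two numbers. Compound 3 `N#Cc1cc2c(nc1N1CCC(C(=O)NS(=O)(=O)Cc3ccccc3)CC1)CNC2=O` reports only a limit, > 300000 nM.

Compound 4 `N#Cc1cc2c(nc1N1CCC(C(=O)NS(=O)(=O)c3ccc(Cl)s3)CC1)COC2=O` has not yet been measured. It has 5-chlorothiophen-2-yl in place of 4-cyanobenzyl on a sulfonyl sulfur.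

Within the data shown here, one measured step bears on this change. Putting 4-cyanophenyl in place of 2-fluorophenyl on a saturated chain carbon bound to a sulfonyl sulfur gave a 2.7-fold lower number from compound 1 to compound 2 (0.43 log units; beyond the scatter), a modest step. That step kept the saturated chain carbon, whereas in compound 4 the new ring stands on the sulfonyl sulfur itself, so the change is larger than anything measured so far. Among the measured compounds shown here, the data therefore give no firm direction, and the modest size of a 2.7-fold lower number from compound 1 to compound 2 (0.43 log units; beyond the scatter) is the only guide to scale. A small loss is expected at most, with wide uncertainty on either side, and the estimated step is a 1.3-fold higher number from compound 2 to compound 4 (0.13 log units; within the scatter). For compound 4 the expected value in this assay is 12000 nM, with an estimated range from 2500 nM to 60000 nM.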

Compound 4, half-maximal inhibitory concentration: 4470 nM
The estimate for compound 4 lay 2.7-fold (0.43 log units) above the measured number; the range from low to high includes it.
By their numbers in this assay, from the lowest: compounds 4 and 2 (each within the scatter of the next); then compound 1. At a limit, above all of these: compound 3.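

In this assay, 5-chlorothiophen-2-yl in place of 4-cyanobenzyl on the sulfonyl sulfur gives a 2.0-fold lower number from compound 2 to compound 4 (0.30 log units; within the scatter), so this assay does not separate the two groups, even though the entering group has fewer heavy atoms and no saturated chain carbon. Set against 2-fluorobenzyl, the same group gives a 5.3-fold lower number from compound 1 to compound 4 (0.72 log units; beyond the scatter), which shows for the first time that an aromatic ring standing directly on the sulfonyl sulfur, and a five-membered one at that, can hold a number at the low end of the series. The compounds shown offer no measurement that explains why these numbers come out as they do.

Among these compounds, whether the chlorine contributes stays open, since no compound here has a bromine, a methyl group or a plain hydrogen in its place on the thiophene. From the compounds shown here alone, it is also open how a phenyl ring set directly on the sulfonyl sulfur, or a longer chain carrying the ring there, would compare on the same core.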